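Trimming the Amide Side Chain: Compound 3 to Compound 4

This account rests on a few compounds, and the source may have more. Where it says the series, first, only, none or still open, it means among the compounds named here.

Compound 1 `O=C(CN1CCCCC1)Nc1ccc(-c2nc3cc(C(F)(F)F)ccc3[nH]2)cc1` gives 12000 nM in an ADME assay on BHK cells (Mesocricetus auratus) for cytotoxicity, read by MTT assay, with a stated time of 96 h; a lower number here means that less compound is tolerated, a higher number that more compound is tolerated.
Compound 2 `CC(=O)Nc1ccc(-c2nc3ccccc3[nH]2)cc1` reaches only a limit, > 100000 nM, in this assay.
Compound 3 `O=C(CN1CCCCC1)Nc1ccc(-c2nc3ccccc3[nH]2)cc1` gives 31000 nM in this assay.

Among the two plain numbers in this assay, compound 3 stands highest; the nearest number is reached by a 2.6-fold higher number from compound 1 to compound 3 (0.41 log units; beyond the scatter). Compound 2 shows only a limit. Compound 4 `CCC(=O)Nc1ccc(-c2nc3ccccc3[nH]2)cc1` differs from compound 3 by methyl in place of piperidin-1-yl on a saturated chain carbon bound to a carbonyl carbon. The step that bears on this change is an at least 3.2-fold lower number from compound 2 to compound 3 (0.50 log units; beyond the scatter), which points toward a higher number once the piperidin-1-yl is gone. Compound 4 is therefore expected to move back toward compound 2, with a 3.2-fold higher number from compound 3 to compound 4 (0.51 log units; beyond the scatter). Compound 4 is estimated at 100000 nM, within 40000 nM to 300000 nM, and may itself be reported only as a limit.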

Compound 4, half-maximal cytotoxic concentration: >= 100000 nM
Compound 4 was reported as a limit (the forecaster's own chance of this, stated with the estimate: 60%); the middle value sits exactly at the limit.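

In this assay, methyl in place of piperidin-1-yl gives an at least 3.2-fold higher number from compound 3 to compound 4 (0.50 log units; beyond the scatter), so the lower number of compound 3 now stands out against a second small group at this place, not only against the hydrogen of compound 2. Compound 4 gives a limit rather than a number: the limit of >= 100000 nM in this assay, at which 1 of the 4 values shown sits. Compound 2 and compound 4 are both limits, and the step between them cannot be read.

From the compounds shown here alone, whether the lower number follows the ring or its nitrogen stays open: a cyclohexyl group or an open-chain amine such as dimethylamino at this place would separate the two.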